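Methyl on the saturated ring: compound 2 to compound 3

The compounds below may be only part of what the source reports. "The series", "measured", "known", "first", "only" and "open" are said of these compounds alone.

Within the data shown here, compound 1 `COc1cc2c(Oc3ccc(NC(=O)c4nn(-c5ccccc5OC(F)(F)F)c(=O)cc4C)cc3F)ccnc2cc1OCCCN1CCC(C)CC1` and compound 2 `COc1cc2c(Oc3ccc(NC(=O)c4nn(-c5ccc(Cl)cc5)c(=O)cc4C)cc3F)ccnc2cc1OCCCN1CCCCC1` share a common core and differ at two places, so no single step links them. In a functional assay on HT-29 cells (Homo sapiens) for inhibition, read by MTT assay, with a stated time of 72 h (on this read-out lower numbers stand for stronger inhibition and higher numbers for weaker inhibition), compound 1 gives 250 nM and compound 2 gives 360 nM; the two numbers lie within the scatter of each other, and on these two measurements compound 2 cannot be set apart from compound 1. Compound 3 `COc1cc2c(Oc3ccc(NC(=O)c4nn(-c5ccc(Cl)cc5)c(=O)cc4C)cc3F)ccnc2cc1OCCCN1CCC(C)CC1` is compound 2 with methyl in place of hydrogen on a saturated ring carbon, the change reading piperidin-1-yl to 4-methylpiperidin-1-yl. Among the measured compounds shown here, no measured pair shows this change on its own; compound 1 carries the 4-methylpiperidin-1-yl group but differs from compound 2 elsewhere as well, so it gives no clean reference. The step from compound 2 to compound 3 in this assay is expected to be a 1.2-fold lower number from compound 2 to compound 3 (0.06 log units; within the scatter), nothing beyond the scatter in either direction. For compound 3 the estimate in this assay is 310 nM, with a range from 120 nM to 800 nM.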

Compound 3, half-maximal inhibitory concentration: 180 nM
The estimate for compound 3 lay 1.7-fold (0.24 log units) above the measured number; the measured number falls inside the stated range.
By their numbers in this assay, from the lowest: compounds 3, 1 and 2 (each within the scatter of the next).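

Among these compounds, the first clean reading of this change comes from methyl in place of hydrogen on a saturated ring carbon, three ring bonds from the ring nitrogen: in this assay the pair shows a 2.0-fold lower number from compound 2 to compound 3 (0.30 log units; within the scatter) and so leaves the two compounds inseparable. With 4-methylpiperidin-1-yl held constant, 4-chlorophenyl in place of 2-(trifluoromethoxy)phenyl on an aromatic nitrogen gives a 1.4-fold lower number from compound 1 to compound 3 (0.14 log units; within the scatter) and so also separates nothing, which means neither single change moves the number beyond the scatter in this series. No measurement here bears on why these steps are the size they are.

As far as these compounds go, whether a hydroxyl, a primary amine or an ethyl on that same ring carbon would move the number beyond the scatter remains open. From the compounds shown here alone, whether the methyl step reads the same with 2-(trifluoromethoxy)phenyl on the aromatic nitrogen also remains open.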